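Widening the amine ring on a fused sulfone core

The compounds below may be only part of what the source reports. "The series", "measured", "known", "first", "only" and "open" are said of these compounds alone.

Measured so far:
compound 1, `CN1CCC(n2cc(S(=O)(=O)c3cccc(F)c3)c3cccnc32)C1`: 54%
compound 2, `O=S(=O)(C1=C(Cl)NC2SC=CN12)c1cn(C2CCNC2)c2ncccc12`: 32%
compound 3, `CN1CCCC(n2cc(S(=O)(=O)c3cccc(C(F)(F)F)c3)c3cccnc32)C1`: 66%

In a functional assay on HeLa cells for agonist activity at 5-hydroxytryptamine receptor 6 (Homo sapiens), read by cAMP accumulation and immunoassay (a higher number here means a larger maximal response, a lower number a smaller maximal response), compound 2 gives the lowest of the three numbers, and its gaps to compound 1 and to compound 3 both lie beyond the usual scatter. Compound 4, `CN1CCCC(n2cc(S(=O)(=O)C3=C(Cl)NC4SC=CN34)c3cccnc32)C1`, keeps the core of compound 2 and changes only the group on the aromatic nitrogen: 1-methylpiperidin-3-yl in place of pyrrolidin-3-yl on an aromatic nitrogen. For the measured compounds named here, no pair of measured compounds shows this single change, so its size is not known from the data. Because compound 3 gives 66% with the same 1-methylpiperidin-3-yl group, a moderate rise is expected, a number 16 percentage points higher from compound 2 to compound 4 (beyond the scatter). Compound 4 is therefore estimated at 48%, within 30% to 68%.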

Compound 4, largest response reached (Emax), in percent of the reference or control that the assay uses: 68%
Estimate against measurement, compound 4: 20 percentage points below; the range from low to high includes it.
By their numbers in this assay, from the lowest: compound 2; then compound 1; then compounds 3 and 4 (each within the scatter of the next).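

On the core of compound 2, the group on the aromatic nitrogen strongly shapes the response in this assay: 1-methylpiperidin-3-yl in place of pyrrolidin-3-yl gives a number 36 percentage points higher from compound 2 to compound 4 (beyond the scatter). This single step changes both the ring size and the added methyl, so it cannot show which of the two matters. No measurement shown explains the rise. Open, from the compounds shown here alone, is how piperidin-3-yl, which keeps the six-membered ring without the methyl, would respond on this core. Equally open, going by these compounds, is whether 1-ethylpiperidin-3-yl would hold the response.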